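From Methyl to Methoxy: An Expected Shift in Lipophilicity

The source may hold more compounds than are shown below. What is called first, only, known or untested is meant among the compounds shown, and "the series" means these compounds.

Of the compounds shown here, three have been measured in a physicochemical assay for lipophilicity; on this read-out lower numbers stand for lower lipophilicity and higher numbers for higher lipophilicity. Compound 1 `CNC(=O)c1cc(C(=O)N[C@H]2[C@@H]3C[C@H](O)C[C@@H]32)n([C@@H](C)c2cccc(Cl)c2)n1` gives 3.7. Compound 2 `CNC(=O)c1cc(C(=O)N[C@H]2CC[C@H](O)CC2)c([C@@H](C)c2cccc(C)c2)o1` gives 3.3, and compound 3 `CNC(=O)c1cc(C(=O)N[C@H]2[C@@H]3C[C@@H](O)C[C@@H]32)n([C@@H](C)c2ccccc2)n1` gives 3.2. Among these three numbers compound 2 stands second highest: the reading of compound 3 lies close to it, within the usual scatter of this assay, so the two cannot be told apart, while compound 1 sits clearly higher, beyond the scatter.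

Compound 4 `CNC(=O)c1cc(C(=O)N[C@H]2CC[C@H](O)CC2)c([C@@H](C)c2cccc(OC)c2)o1` has not yet been measured in this assay. It differs from compound 2 in one place only: methoxy in place of methyl on an aromatic carbon. Seen one bond further out, the change reads 3-methylphenyl to 3-methoxyphenyl, on an aromatic carbon of a six-membered aromatic ring of carbon only, meta to a large group. The entering group brings one hydrogen-bond acceptor where the leaving group had none.

Going by the values given here, no measured pair shows this exact change, so the expectation rests on the structures alone. A modest downward step is expected, a number 0.30 log units lower from compound 2 to compound 4 (within the scatter), somewhat beyond the scatter. Compound 4 is therefore estimated at 3, with a likely range from 2.6 to 3.4.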

Compound 4, distribution coefficient: 2.9
Beside the measured number, compound 4's estimate is 0.10 log units above it, within the range that was stated.
By their numbers in this assay, from the lowest: compounds 4, 3 and 2 (each within the scatter of the next, the first and the last beyond it); then compound 1.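

In this assay, going by these compounds alone, the change from 3-methylphenyl to 3-methoxyphenyl gives a number 0.40 log units lower from compound 2 to compound 4 (beyond the scatter) and supplies the one step in this set that isolates a single change; compound 1, compound 2 and compound 3 differ from each other in more than one place. It shows that the reading is sensitive to what sits at this place, on an aromatic carbon meta to a large group: methoxy in place of methyl, with the one hydrogen-bond acceptor it brings, moves the number beyond the scatter. Nothing in hand explains the direction or the size of this step.

What the compounds shown leave open is how far this step carries, since a single pair cannot tell whether the same exchange would give a similar step on the core of compound 1 or the core of compound 3. As far as these compounds go, it is also open how other groups at the same place would read, such as ethoxy, hydroxyl, an amine or a carboxylic acid, and whether a longer chain would extend the step seen with methoxy.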